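A few compounds are considered here, and "the series" means these few. Any claim that something is new, unique, unknown or untested is made for them only; others in the source may bear on it.

In a functional assay on the whole organism for agonist activity, with Mus musculus as the target (a lower number here means that less compound is needed, a higher number that more compound is needed for the effect), compound 1 `CC1CCC(=O)N1CC#CCn1ccnc1` reports only a limit, > 100 mg/kg. Compound 2 `Cn1ccn(CC#CCN2CCCC2)c1=O` gives 6.6 mg/kg and compound 3 `Cn1ccn(CC#CCn2ccnc2)c1=O` gives 3.7 mg/kg, so compound 3 stands level with compound 2. Compound 4 `Cc1cncn1CC#CCn1ccn(C)c1=O` has methyl in place of hydrogen on an aromatic carbon of compound 3, next to the ring atom that bears a large group: methyl in place of hydrogen on an aromatic carbon. Going by the values given here, no measured step adds such a methyl. The nearest guide is a 1.8-fold lower number from compound 2 to compound 3 (0.25 log units; within the scatter), which puts 1H-imidazol-1-yl in place of pyrrolidin-1-yl, so a smaller change at that end of compound 3 is expected to do little. The expected step is a 1.6-fold higher number from compound 3 to compound 4 (0.21 log units; within the scatter), nothing clearly beyond the scatter. With so little to go on, the range stays wide. For compound 4 the estimate is 6 mg/kg, expected between 1.5 mg/kg and 30 mg/kg.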

Compound 4, dose for half-maximal effect: > 100 mg/kg
Compound 4: a limit, no number; the forecaster's own chance of this, stated with the estimate: 15%; middle value at least 16-fold (1.22 log units) away from the limit.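

Methyl in place of hydrogen on an aromatic carbon, next to the ring atom that bears a large group, gives an at least 27-fold higher number from compound 3 to compound 4 (1.43 log units; beyond the scatter) in this assay. The earlier change at this end of the molecule, a 1.8-fold lower number from compound 2 to compound 3 (0.25 log units; within the scatter), gave no hint that so small an addition could matter this much. Compound 4 carries a limit, not a number: the limit of > 100 mg/kg in this assay, at which 2 of the 4 values shown sit.

As far as these compounds go, it remains open whether a fluorine or a methoxy group on this carbon would behave like methyl. Also open, from the compounds shown here alone, is whether methyl on another aromatic carbon of this ring would have the same effect.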